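A few compounds are considered here, and "the series" means these few. Any claim that something is new, unique, unknown or untested is made for them only; others in the source may bear on it.

Values so far in a toxicity assay on L02 cells (Homo sapiens) for cytotoxicity, read by MTT assay, with a stated time of 72 h (a higher number here means a weaker inhibitor, a lower number a stronger inhibitor), are as follows.

Compound 1 `O=C1c2c[n+]([O-])c3ccccc3c2C(=O)c2c1c1ccccc1n2Cc1cn([C@H]2O[C@H](CO)[C@@H](O)[C@H]2O)nn1` gives 950 nM
Compound 2 `O=C1c2c[n+]([O-])c3ccccc3c2C(=O)c2c1c1ccccc1n2CCN1CCCC1` gives 930 nM
Compound 3 `O=C1c2c[n+]([O-])c3ccccc3c2C(=O)c2c1c1ccccc1n2Cc1cn([C@@H]2O[C@H](CO)[C@@H](O)[C@H](O)[C@H]2O)nn1` gives 420 nM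

Compound 3 holds the lowest number of the three, beyond the scatter from both others. Compound 4 `O=C1c2c[n+]([O-])c3ccccc3c2C(=O)c2c1c1ccccc1n2Cc1cn(C[C@@H](O)CO)nn1` carries 2,3-dihydroxypropyl in place of 3,4,5-trihydroxy-6-(hydroxymethyl)oxan-2-yl on an aromatic nitrogen of the five-membered aromatic ring with 3 nitrogen (2,3-dihydroxypropyl in place of 3,4,5-trihydroxy-6-(hydroxymethyl)oxan-2-yl on an aromatic nitrogen) while the shared core stays.

For the measured compounds named here, one measured step bears on this position. Replacing 3,4-dihydroxy-5-(hydroxymethyl)oxolan-2-yl with the oxan-2-yl group gave a 2.3-fold lower number from compound 1 to compound 3 (0.35 log units; beyond the scatter) and that step is modest. Compound 2 carries a different side chain and offers no single-place comparison. The new group has no ring, so a modest move toward a higher number in this assay is expected, though a single step is a thin guide. The expected move is a 1.8-fold higher number from compound 3 to compound 4 (0.25 log units; within the scatter) and it would be of similar modest size. For compound 4 the estimate is 750 nM within an expected range of 280 nM to 2000 nM for now.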

Compound 4, half-maximal inhibitory concentration: 490 nM
Compound 4: middle estimate off by 1.5-fold (0.18 log units), on the high side; measured number inside the range.
By their numbers in this assay, from the lowest: compounds 3, 4, 2 and 1 (each within the scatter of the next, the first and the last beyond it).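

In this assay the open chain replaces the six-membered ring group with a 1.2-fold higher number from compound 3 to compound 4 (0.07 log units; within the scatter) and so, on this aromatic nitrogen of the triazole-type ring, the oxan-2-yl ring and its added hydroxyl groups are not needed to keep the number at the level of compound 3. The same chain, set against the five-membered sugar group, gives a 1.9-fold lower number from compound 1 to compound 4 (0.29 log units; within the scatter) and, with the side arm exchanged for (pyrrolidin-1-yl)methyl, gives a 1.9-fold lower number from compound 2 to compound 4 (0.28 log units; within the scatter) and so compound 4 separates from none of the three, although compound 1 and compound 3 do separate from each other. No measurement available here accounts for these numbers.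

On these data alone, whether the two hydroxyl groups of the chain matter remains open, as a plain propyl chain, a carboxylic acid or an amine at this nitrogen would show. As far as these compounds go, the opposite configuration at the single stereocentre of the chain also remains open.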